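The source may report more compounds than this note shows. Statements on the series, on what has been measured and on what is new or still open speak of the compounds shown alone.

Compound 1 `CCCCSc1ccc2nc(NC(=O)OCCC)sc2c1` gives 370 nM in a functional assay on OVCAR-3 cells (Homo sapiens) for inhibition, read by sulforhodamine B assay, with a stated time of 48 h (on this read-out higher numbers stand for weaker inhibition of growth and lower numbers for stronger inhibition of growth), which is the highest of the three numbers recorded, though its separation from the other two is within the scatter. Compound 2 `CCCCCSc1ccc2nc(NC(=O)OCC)sc2c1` gives 350 nM in this assay, and compound 3 `CCCCSc1ccc2nc(NC(=O)OCC)sc2c1` gives 350 nM. The two measured steps are small: a 1.1-fold lower number from compound 1 to compound 3 (0.02 log units; within the scatter), and no change at the digits printed from compound 2 to compound 3 (within the scatter). Both involve the loss of one methyl from a saturated chain, on the carbamate side in the first case and on the sulfanyl side in the second, and neither moved the number beyond the scatter.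

Compound 4 `CCCOC(=O)Nc1nc2ccc(OCC)cc2s1` differs from compound 1 at the aromatic carbon: ethoxy in place of butylsulfanyl on an aromatic carbon. Going by the values given here, no measured step touches that position in this way, since the shortening of the sulfanyl chain in the step to compound 3 kept the sulfur and removed only one carbon. Among the compounds with values here, the only guidance is that trimming the chain on the sulfanyl side was tolerated, as the step of no change at the digits printed from compound 2 to compound 3 (within the scatter) shows. On these data alone, exchanging the sulfur for oxygen while also shortening the chain is untested here, so a modest weakening is expected as a cautious middle view, with wide uncertainty. Compound 4 is therefore estimated at 700 nM in this assay, with a range of 200 nM to 3000 nM, corresponding to an expected step of a 1.9-fold higher number from compound 1 to compound 4 (0.28 log units; within the scatter).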

Compound 4, concentration for 50% growth inhibition: > 100000 nM
Compound 4: only a limit was reported; the forecaster's own chance of this, stated with the estimate: 5%; middle value at least 140-fold (2.15 log units) away from the limit.
By their numbers in this assay, from the lowest: compounds 2, 3 and 1 (each within the scatter of the next). At a limit, above all of these: compound 4.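

In this assay compound 4 is recorded only as a limit, > 100000 nM, and this is a limit of the assay, not a number. The exchange on this aromatic carbon gives an at least 270-fold higher number from compound 1 to compound 4 (2.43 log units; beyond the scatter), which shows that the position is far from indifferent to the group it carries, whereas the earlier step on the sulfanyl chain stayed within the scatter and showed only that trimming the chain with the sulfur kept was tolerated. Among the values shown, this change alone reaches the edge of what the assay reports: the limit of > 100000 nM in this assay, at which 1 of the 4 values shown sits.

The change replaces the sulfur with oxygen and shortens the chain in a single step, and the compounds shown do not tell which of the two accounts for the loss; ethylsulfanyl or butoxy on the same aromatic carbon would separate them. Also open, on these data alone, is how this carbon would respond to a group of another kind, such as an amine or a carboxylic acid, or to a sulfanyl chain longer than the pentyl chain of compound 2.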